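The source may report more compounds than this note shows. Statements on the series, on what has been measured and on what is new or still open speak of the compounds shown alone.

Measured so far in a functional assay on HCT-116 cells (Homo sapiens) for cytotoxicity, read by sulforhodamine B assay, with a stated time of 24 h; on this read-out higher numbers stand for weaker inhibition and lower numbers for stronger inhibition:
- compound 1, `N/N=C1\C(=O)Nc2ccc(S(=O)(=O)N3CCOCC3)cc21`, gives 36300 nM
- compound 2, `O=C1Nc2ccc(S(=O)(=O)N3CCOCC3)cc2/C1=N/NS(=O)(=O)c1ccccc1`, gives 13300 nM
- compound 3, `O=C1Nc2ccc(S(=O)(=O)N3CCOCC3)cc2/C1=N/c1ccc(O)cc1`, gives 27300 nM

All three share one core and differ only at the double-bonded nitrogen. Compound 3 stands second highest of the three numbers: its nearest neighbour is compound 1, as a 1.3-fold lower number from compound 1 to compound 3 (0.12 log units; within the scatter) shows, a gap within the scatter; compound 2 is furthest, with a 2.1-fold higher number from compound 2 to compound 3 (0.31 log units; beyond the scatter), a modest but real step.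

Compound 4, `O=C1Nc2ccc(S(=O)(=O)N3CCOCC3)cc2/C1=N/c1cccc(C(F)(F)F)c1`, changes the group on the same double-bonded nitrogen: 3-(trifluoromethyl)phenyl in place of 4-hydroxyphenyl on a double-bonded nitrogen. For the measured compounds named here, no measured step tests this exact swap. The two steps that bear on it, a 1.3-fold lower number from compound 1 to compound 3 (0.12 log units; within the scatter) and a 2.1-fold higher number from compound 2 to compound 3 (0.31 log units; beyond the scatter), both alter the group at that nitrogen and both stayed small, so changes there have so far moved this assay little. The expectation for compound 4 is therefore a step of about a 1.2-fold lower number from compound 3 to compound 4 (0.09 log units; within the scatter), not clearly beyond the scatter. Compound 4 is estimated at 22000 nM, with a range from 8000 nM to 60000 nM.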

Compound 4, half-maximal inhibitory concentration: 15900 nM
Beside the measured number, compound 4's estimate is 1.4-fold (0.14 log units) above it, and the stated range covers the measured number.
By their numbers in this assay, from the lowest: compounds 2, 4, 3 and 1 (each within the scatter of the next, the first and the last beyond it).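

In this assay replacing 4-hydroxyphenyl, with its hydrogen-bond donor and acceptor, by 3-(trifluoromethyl)phenyl, which has neither, gives a 1.7-fold lower number from compound 3 to compound 4 (0.23 log units; within the scatter) and so losing both does not clearly shift the number. Very different groups on the double-bonded nitrogen can also give matching results, as a 1.2-fold higher number from compound 2 to compound 4 (0.08 log units; within the scatter) stays within the scatter. Only the comparison with the amino group clears the scatter, with a 2.3-fold lower number from compound 1 to compound 4 (0.36 log units; beyond the scatter) as a modest step, and compound 3 goes against reading this as a general gain for phenyl groups over amino, since its own gap to compound 1 lies within the scatter.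

As far as these compounds go, whether an amine or a carboxylic acid on this phenyl ring, or a longer chain on the double-bonded nitrogen, would move the number further stays open. Nothing available explains these small steps.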